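Compound 3 to compound 4: replacing the bromide chain end

A few compounds are considered here, and "the series" means these few. Any claim that something is new, unique, unknown or untested is made for them only; others in the source may bear on it.

Values in a functional assay on PC-3 cells (Homo sapiens) for inhibition, read by MTT assay, with a stated time of 48 h; on this read-out higher numbers stand for weaker inhibition and lower numbers for stronger inhibition:
- Compound 1 `COc1ccc(-c2coc3cc(OCCCSC(=S)N4CCN(C(C)=O)CC4)ccc3c2=O)cc1`: 4310 nM
- Compound 2 `COc1ccc(-c2coc3cc(OCCCSC(=S)N4CCN(c5ccccn5)CC4)ccc3c2=O)cc1`: 17400 nM
- Compound 3 `COc1ccc(-c2coc3cc(OCCCCCBr)ccc3c2=O)cc1`: 44800 nM

Compound 3 stands highest of the three at 44800 nM, ahead of compound 2 at 17400 nM and compound 1 at 4310 nM. The next compound is compound 4 `COc1ccc(-c2coc3cc(OCCCSC(=S)N4CCOCC4)ccc3c2=O)cc1`, and the change is a group of 9 heavy atoms (5 carbon, 1 nitrogen, 1 oxygen, 2 sulfur; one six-membered non-aromatic ring with 2 hetero atoms) in place of a group of 3 heavy atoms (2 carbon, 1 bromine; no ring), on a saturated chain carbon, three bonds along the chain from an oxygen on an aromatic ring. Compound 1 and compound 2 also carry a six-membered non-aromatic ring with 2 hetero atoms in this place, and both give lower numbers than compound 3. Among the compounds with values here, the only measured step is a 4.0-fold higher number from compound 1 to compound 2 (0.61 log units; beyond the scatter). It does not cover the change itself, so it indicates the likely spread among such ring compounds, not the direction. The direction rests on the values of compound 1 and compound 2 alone. A moderate move towards stronger inhibition in this assay is therefore expected, with an estimated step of a 5.0-fold lower number from compound 3 to compound 4 (0.70 log units; beyond the scatter). For compound 4 the estimated value is 9000 nM, with an expected range of 3000 nM to 27000 nM.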

Compound 4, half-maximal inhibitory concentration: 27400 nM
Compound 4: middle estimate off by 3.0-fold (0.48 log units), on the low side, and the stated range ends below it.
By their numbers in this assay, from the lowest: compound 1; then compounds 2, 4 and 3 (each within the scatter of the next, the first and the last beyond it).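

In this assay, the ring-bearing group in place of 2-bromoethyl gives a 1.6-fold lower number from compound 3 to compound 4 (0.21 log units; within the scatter), so a six-membered non-aromatic ring with 2 hetero atoms at this place does not by itself separate compound 4 from compound 3. Among the ring compounds, morpholin-4-yl in place of 4-(pyridin-2-yl)piperazin-1-yl gives a 1.6-fold higher number from compound 2 to compound 4 (0.20 log units; within the scatter), while morpholin-4-yl in place of 4-acetylpiperazin-1-yl gives a 6.4-fold higher number from compound 1 to compound 4 (0.80 log units; beyond the scatter). The lower number of compound 1 therefore goes with its 4-acetylpiperazin-1-yl group and is not shared by the morpholin-4-yl ring of compound 4.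

No supporting data explain this difference. Still open, on these data alone, is whether a benzoyl or methylsulfonyl group in place of acetyl on the ring nitrogen, or a longer chain from the aromatic oxygen, would hold the level of compound 1 at 4310 nM.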